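Trifluoroacetyl thiophenes: from compound 1 to compound 4

The source may report more compounds than this note shows. Statements on the series, on what has been measured and on what is new or still open speak of the compounds shown alone.

Measured in an assay on isolated protein for inhibition of protein deacetylase HDAC6 (Homo sapiens); on this read-out higher numbers stand for weaker inhibition and lower numbers for stronger inhibition:
Compound 1 `O=C(c1ccc(-c2nc(-c3ccccn3)no2)s1)C(F)(F)F` gives 500 nM.
Compound 2 `O=C(NCc1ccccc1)c1ccc(C(=O)C(F)(F)F)s1` gives 370 nM.
Compound 3 `O=C(c1ccc(-c2ncc(-c3ccccc3)s2)s1)C(F)(F)F` gives 1350 nM.

Compound 1 stands second highest of the three numbers. Its nearest neighbour is compound 2, whose number lies within the scatter of that of compound 1, so no order between the two can be claimed. Compound 3 gives the highest number, beyond the scatter from compound 1. Among the measured compounds shown here, no pair among the three differs in a single place, so no step between measured compounds is available to lean on.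

Compound 4 `O=C(c1ccc(-c2nc(Cc3cccs3)no2)s1)C(F)(F)F` has not yet been measured in this assay. It differs from compound 1 as follows: (thiophen-2-yl)methyl in place of pyridin-2-yl on an aromatic carbon. The three measured compounds share the core of compound 1 and vary only at the far end, and their numbers span a modest range. For the measured compounds named here, with no matched step to guide it, the expectation for the change from compound 1 to compound 4 is a small step, most likely within the scatter, with a slight lean toward a higher number: the step is expected as a 1.2-fold higher number from compound 1 to compound 4 (0.08 log units; within the scatter). Compound 4 is accordingly expected to give about 600 nM in this assay, in a range from 250 nM to 1500 nM.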

Compound 4, half-maximal inhibitory concentration: 170 nM
Beside the measured number, compound 4's estimate is 3.5-fold (0.55 log units) above it; measured number below the stated range.
By their numbers in this assay, from the lowest: compound 4; then compounds 2 and 1 (each within the scatter of the next); then compound 3.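

In this assay, replacing pyridin-2-yl with (thiophen-2-yl)methyl on the aromatic carbon between two ring nitrogen atoms gives a 2.9-fold lower number from compound 1 to compound 4 (0.47 log units; beyond the scatter). Among the compounds shown here, this is the only single-place step so far, and it shows that the group at this carbon can move the number beyond the scatter while the rest of compound 1 stays unchanged. Nothing at hand accounts for the step.

The change swaps the ring and adds a methylene link at once, so their separate shares remain unresolved; pyridin-2-ylmethyl or a directly attached thiophen-2-yl would separate them. Also open, from the compounds shown here alone, is how this carbon responds to groups without a ring, such as an amine or a longer alkyl chain.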